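Swapping hydroxy for chloro on the long chain

This account rests on a few compounds, and the source may have more. Where it says the series, first, only, none or still open, it means among the compounds named here.

Among the compounds with values here, in a functional assay on SW480 cells (Homo sapiens) for antiproliferative activity, read by MTT assay, with a stated time of 48 h (on this read-out higher numbers stand for weaker inhibition and lower numbers for stronger inhibition), compound 3 `CCCCCCCCCC(CCO)n1cnc2c(Cl)ncnc21` gives 1150 nM as the only true number so far. Compound 1 `CCC(CCO)n1cnc2c(Cl)ncnc21` stands at > 50000 nM as a limit of the assay. Compound 2 `CCCCCC(CCO)n1cnc2c(Cl)ncnc21` stands at > 50000 nM as a limit too. The measured steps are a step that the two limits leave unreadable from compound 1 to compound 2 and an at least 43-fold lower number from compound 1 to compound 3 (1.63 log units; beyond the scatter) and an at least 43-fold lower number from compound 2 to compound 3 (1.63 log units; beyond the scatter) and all of them alter the chain alone. Compound 4 `CCCCCCCCCC(CCCl)n1cnc2c(Cl)ncnc21` keeps the chain of compound 3 and differs by chloro in place of hydroxy on a saturated chain carbon, three bonds along the chain from an aromatic nitrogen at its end. Within the data shown here, no measured step covers this exchange, so only a modest shift toward weaker inhibition is assumed. The expected change is a 2.2-fold higher number from compound 3 to compound 4 (0.34 log units; beyond the scatter) with wide uncertainty. Compound 4 is estimated at 2500 nM within a range from 600 nM to 15000 nM in this assay for now.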

Compound 4, half-maximal inhibitory concentration: 7180 nM
Compound 4: the middle estimate sits 2.9-fold (0.46 log units) below what was measured; measured number inside the range.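

In this assay, chloro in place of hydroxy on a saturated chain carbon, three bonds along the chain from an aromatic nitrogen, brings a 6.2-fold higher number from compound 3 to compound 4 (0.80 log units; beyond the scatter). Within the data shown here, the earlier compounds varied only the chain, so this is the first sign that the read-out also responds to the group at this place, and the change still leaves a true number rather than a limit. Nothing given here explains this shift. As far as these compounds go, whether an amine or a carboxylic acid at this place would move the number further stays open. So does what a longer chain would do with either end group.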